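The source may hold more compounds than are shown below. What is called first, only, known or untested is meant among the compounds shown, and "the series" means these compounds.

Compound 1 `Cc1nn(C)c2c1C(c1ccccc1Cl)=NCCN2` is measured in a functional assay on the whole organism for positive allosteric modulation, with Rattus norvegicus as the target (a lower number here means that less compound is needed, a higher number that more compound is needed for the effect), where compound 1 gives 2.5 mg/kg. Compound 2 `Cc1nn(C)c2c1C(c1ccccc1Cl)=NCCN2CCCN(C)C` carries the change (3-(dimethylamino)propyl in place of hydrogen on a nitrogen on an aromatic ring in a ring). In this assay compound 2 reaches only a limit rather than a number, > 10 mg/kg. Among the compounds with values here, the step of an at least 4.0-fold higher number from compound 1 to compound 2 (0.60 log units; beyond the scatter) is the one measured example of this change, and its full size stays open because of the limit of > 10 mg/kg in this assay, at which 1 of the 3 values shown sits.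

Compound 3 `CCc1nn(C)c2c1C(c1cccc(F)c1)=NCCN2` has a different core from compound 1; the difference between the two cores is not broken down here. In this assay compound 3 gives 2.5 mg/kg, level with compound 1 at the digits printed.

Compound 4 `CCc1nn(C)c2c1C(c1cccc(F)c1)=NCCN2CCCN(C)C` is not yet measured and carries 3-(dimethylamino)propyl in place of hydrogen on a nitrogen on an aromatic ring in a ring. Within the data shown here, this is the same kind of change as the one from compound 1 to compound 2, though not the same: around the place, the ring atom with three ring bonds bears a 3-fluorophenyl group in compound 4, where in compound 2 it bears a 2-chlorophenyl group. Among the measured compounds shown here, a step of about a 4.0-fold higher number from compound 3 to compound 4 (0.60 log units; beyond the scatter) is expected in this assay because compound 3 gives 2.5 mg/kg and because the only example of this change so far is an at least 4.0-fold higher number from compound 1 to compound 2 (0.60 log units; beyond the scatter). Compound 4 is therefore estimated at 10 mg/kg, between 5 mg/kg and 20 mg/kg, and it is expected that only a limit and no number may again be reported.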

Compound 4, minimum effective dose: > 10 mg/kg
Compound 4 was reported as a limit (the forecaster's own chance of this, stated with the estimate: 70%); the middle value sits exactly at the limit.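

In this assay, 3-(dimethylamino)propyl in place of hydrogen on a nitrogen on an aromatic ring in a ring gives an at least 4.0-fold higher number from compound 3 to compound 4 (0.60 log units; beyond the scatter), and this is the second measured example of the change, now on the core of compound 3. The change therefore raises the number in the same direction on both cores shown, which is as far as the transfer can be claimed, but this does not show that the step has the same size on the two cores: the same change on two cores in this assay, an at least 4.0-fold higher number (0.60 log units; beyond the scatter) from compound 1 to compound 2 and an at least 4.0-fold higher number (0.60 log units; beyond the scatter) from compound 3 to compound 4; the limit leaves it open whether they differ. Neither step has a known end, and the compounds can no longer be ranked against each other at that end of the scale: the limit of > 10 mg/kg in this assay, at which 2 of the 4 values shown sit.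

The compounds shown leave open which part of the new group goes with the higher number, since a plain propyl chain without the amine, a shorter or longer chain ending in the same dimethylamine, or a chain ending in a carboxylic acid does not appear among them. They also leave open whether the change behaves alike on any core other than these two.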